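Two aryl ureas and a proposed difluoro analogue

The source may report more compounds than this note shows. Statements on the series, on what has been measured and on what is new or still open speak of the compounds shown alone.

Measured compounds:
- compound 1 `CCc1cccc(NC(=O)N[C@H](C)c2ccccc2)c1` gives 71% in an ADME assay on the whole organism with Oryza sativa as the target, tested at 1 uM; a higher number here means a weaker effect of the compound at the concentration tested, a lower number a stronger effect
- compound 2 `C[C@@H](NC(=O)Nc1cccc(F)c1)c1ccccc1` gives 95% in this assay

Compound 2 stands highest of the two numbers; the nearest is compound 1, and the step of a number 24 percentage points higher from compound 1 to compound 2 (beyond the scatter) lies beyond the scatter. That step is the only measured one, and it swaps ethyl for fluoro; it says nothing directly about adding a further fluoro to a carbon that already carries none.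

Compound 3 `C[C@@H](NC(=O)Nc1cc(F)cc(F)c1)c1ccccc1` differs from compound 2 by fluoro in place of hydrogen on an aromatic carbon. For the measured compounds named here, no measured step bears on this change, so the expectation rests on compound 2 alone, whose value in this assay already sits close to the top of the scale. The expected step is a number 3 percentage points lower from compound 2 to compound 3 (within the scatter). Compound 3 is therefore estimated at 92%, with a range from 78% to 100%.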

Compound 3, a percentage reported as activity, at one concentration (the size of the read-out at that concentration, not a potency): 98%
Estimate against measurement, compound 3: 6 percentage points below; measured number inside the range.
By their numbers in this assay, from the lowest: compound 1; then compounds 2 and 3 (each within the scatter of the next).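

Within this assay, fluoro in place of hydrogen on an aromatic carbon, meta to a fluoro group, gives a number 3 percentage points higher from compound 2 to compound 3 (within the scatter) and adds a reading at a position the earlier compounds left unexplored. At this position, then, the second fluoro leaves the number of compound 2 unchanged within the scatter, and compound 2 and compound 3 cannot be told apart in this read-out. No supporting data are available to explain this result.

Still open, on these data alone, is whether a larger or differently charged group at this position, such as an ethyl group, a methoxy group, an amine or a carboxylic acid, would move the number away from the top of the scale. The same question applies to replacing both fluoro groups at once, which the single steps shown here do not address.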